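This account rests on a few compounds, and the source may have more. Where it says the series, first, only, none or still open, it means among the compounds named here.

Working notes on a small series sharing one core.

Compound 1, `COc1nc(-c2cc3ccccc3o2)cc(-c2ccc(Br)cc2)c1C#N`, is measured in a functional assay on aorta (strain Wistar) for inhibition, with Thoracic aorta (Rattus norvegicus) as the target (a higher number here means a weaker inhibitor, a lower number a stronger inhibitor), and gives 298000 nM. Compound 2, `CCOc1nc(-c2cc3ccccc3o2)cc(-c2ccc(Br)cc2)c1C#N`, gives 227000 nM in this assay. Between these two the change is methyl in place of hydrogen on a saturated chain carbon bound to an oxygen on an aromatic ring; the step is a 1.3-fold lower number from compound 1 to compound 2 (0.12 log units; within the scatter), so the two values sit together within the usual scatter. Compound 3, `COc1ccc(-c2cc(-c3cc4ccccc4o3)nc(OC)c2C#N)c(OC)c1`, gives 425000 nM in this assay. The difference between the core of compound 1 and the core of compound 3 is not broken down here; the two values lie within the scatter of each other, as do those of compound 3 and compound 2, so no order among the three is claimed.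

Compound 4, `CCOc1nc(-c2cc3ccccc3o2)cc(-c2ccc(OC)cc2OC)c1C#N`, has not yet been measured in this assay. It differs from compound 3 by methyl in place of hydrogen on a saturated chain carbon bound to an oxygen on an aromatic ring. The place of this change is the same, word for word, as the place of the change from compound 1 to compound 2, so the same change is repeated on a different core; it occurs only twice among the compounds here.

For compound 4 the expected step is a 1.3-fold lower number from compound 3 to compound 4 (0.11 log units; within the scatter), judged to lie within the scatter. This expectation rests on compound 1 and compound 2 because a 1.3-fold lower number from compound 1 to compound 2 (0.12 log units; within the scatter), a step that did not move the number beyond the scatter. Among the measured compounds shown here, with only one precedent, and none on the core of compound 3, the range is kept wide. Compound 4 is estimated at 330000 nM in this assay. The estimate for compound 4 is expected to fall between 170000 nM and 650000 nM.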

Compound 4, half-maximal inhibitory concentration: 488000 nM
Estimate against measurement, compound 4: 1.5-fold (0.17 log units) below, and the stated range covers the measured number.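

Placing methyl on the saturated chain carbon bound to an oxygen on an aromatic ring, the change from methoxy to ethoxy, gives a 1.1-fold higher number from compound 3 to compound 4 (0.06 log units; within the scatter), and the step on this second core does not differ from the earlier one: the same change on two cores in this assay, a 1.3-fold lower number (0.12 log units; within the scatter) from compound 1 to compound 2 and a 1.1-fold higher number (0.06 log units; within the scatter) from compound 3 to compound 4, 1.5-fold (0.18 log units) apart, within the scatter of two such steps. In this assay, the change therefore leaves the number within the scatter on both cores shown, but two pairs cannot show that this holds on other cores, and neither step gives a direction that can be read. Among the compounds shown here, the one step here beyond the scatter belongs to a different change, 2,4-dimethoxyphenyl in place of 4-bromophenyl on an aromatic carbon, which gives a 2.1-fold higher number from compound 2 to compound 4 (0.33 log units; beyond the scatter); this is a modest step from a single pair, so it sets no trend for that change.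

The compounds shown leave open whether a longer chain, such as propyl or butyl, in place of the methyl or ethyl of the alkoxy group would keep the number within the scatter. They also leave open what an amine or a carboxylic acid at that place would do in this assay, and whether the same change would behave alike on a core carrying either group.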